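The source may hold more compounds than are shown below. What is called first, only, known or untested is meant among the compounds shown, and "the series" means these compounds.

Measured so far in a functional assay on SW480 cells (Homo sapiens) for cytotoxicity, read by MTT assay, with a stated time of 24 h; on this read-out higher numbers stand for weaker inhibition and lower numbers for stronger inhibition:

Compound 1 `C=CC1=C(C(=O)O)C(c2ccc(F)cc2)OC1` gives only the limit > 100000 nM.
Compound 2 `C=CC1=C(C(=O)NCc2ccccc2)C(c2ccc(F)cc2)OC1` gives only the limit > 100000 nM.
Compound 3 `C=CC1=C(C(=O)NCc2ccccc2)C(c2ccc(Cl)c(Cl)c2)OC1` gives only the limit > 100000 nM.

None of the three gave a number in this assay; each stopped at a limit, and the limit of > 100000 nM in this assay, at which 3 of the 3 values shown sit, gathers all three values at that same point. The change from compound 2 to compound 1 is hydroxy in place of benzylamino on a carbonyl carbon, and its step that the two limits leave unreadable from compound 2 to compound 1 cannot be read, since both ends are limits. Compound 2 and compound 3 differ in their cores by 3,4-dichlorophenyl in place of 4-fluorophenyl on a saturated ring carbon, and that step, a step that the two limits leave unreadable from compound 2 to compound 3, is likewise unreadable for the same reason.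

Compound 4 `C=CC1=C(C(=O)O)C(c2ccc(Cl)c(Cl)c2)OC1` has not yet been measured. It differs from compound 3 by hydroxy in place of benzylamino on a carbonyl carbon, which is the same change as that from compound 2 to compound 1, made at the same kind of place. Because compound 3 sits at > 100000 nM and compound 2 and compound 1 both sat at the limit (the limit of > 100000 nM in this assay, at which 3 of the 3 values shown sit), compound 4 is expected to stay at the limit as well, with a step that the limit leaves unreadable from compound 3 to compound 4 that is expected to be essentially flat. The estimate for compound 4 in this assay is therefore 150000 nM, most likely reported only as a limit.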

Compound 4, half-maximal inhibitory concentration: > 100000 nM
Compound 4: only a limit was reported; the forecaster's own chance of this, stated with the estimate: 85%; the middle value lies beyond the limit too.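

In this assay compound 4 gives only the limit > 100000 nM and no number. Compound 3 also stopped at a limit, so no new step can be read between compound 3 and compound 4. The compounds shown leave open whether hydroxy or benzylamino on the carbonyl carbon, or 3,4-dichlorophenyl or 4-fluorophenyl, changes cytotoxicity at all.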